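The compounds below may be only part of what the source reports. "The series", "measured", "known", "first", "only" and "open" are said of these compounds alone.

Compounds 1, 2 and 3 share one core, shown for compound 1 `O=C1Nc2cc(Cl)ccc2/C1=C\c1cccc(OCc2cn(Cc3ccccc3)nn2)c1`, compound 2 `O=C1Nc2ccc(Br)cc2/C1=C/c1cccc(OCc2cn(Cc3ccccc3)nn2)c1` and compound 3 `O=C1Nc2ccc([N+](=O)[O-])cc2/C1=C\c1cccc(OCc2cn(Cc3ccccc3)nn2)c1`, and differ only in the group carried on the fused ring. In a functional assay on HeLa cells (Homo sapiens) for inhibition, read by MTT assay, with a stated time of 48 h (on this read-out higher numbers stand for weaker inhibition and lower numbers for stronger inhibition), compound 1 gives > 50000 nM, which is a limit of the assay and not a number. Compound 2 is also recorded only as a limit, > 50000 nM. Compound 3 likewise stands at a limit, > 50000 nM. Hence the limit of > 50000 nM in this assay, at which 3 of the 3 values shown sit: no compound in the set has a measured number in this assay, and no step between measured compounds can be stated.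

Compound 4 `CC(=O)c1ccc2c(c1)/C(=C\c1cccc(OCc3cn(Cc4ccccc4)nn3)c1)C(=O)N2` differs from compound 3 by acetyl in place of nitro on an aromatic carbon. Within the data shown here, no measured step in the set bears on this change, and all three values so far sit at the limit. The step expected in this assay is a number no higher from compound 3 to compound 4 (the limit leaves the size open), which is none beyond the scatter, with compound 4 expected to remain at the limit. Compound 4 is estimated at 50000 nM, with a range from 15000 nM to 200000 nM.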

Compound 4, half-maximal inhibitory concentration: > 50000 nM
Compound 4: only a limit was reported; the forecaster's own chance of this, stated with the estimate: 75%; the middle value lies on the limit itself.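

No step can be read between compound 3 and compound 4, since each stands only at a limit of the assay: the limit of > 50000 nM in this assay, at which 4 of the 4 values shown sit.

The compounds shown leave open how acetyl and nitro compare in this assay, and whether any group on the fused ring gives a readable number there.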